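The source may hold more compounds than are shown below. What is called first, only, known or untested is meant among the compounds shown, and "the series" means these compounds.

Measured in a functional assay on A549 cells (Homo sapiens) for inhibition, read by MTT assay, with a stated time of 48 h (a higher number here means a weaker inhibitor, a lower number a stronger inhibitor), so far
- compound 1 `CCN(CC)CCCC(C)NC(=O)OC1=C(c2cccc3ncccc23)Oc2cc3ccccc3cc2-n2cccc21` gives 1380 nM
- compound 2 `CN1CCN(C(=O)OC2=C(c3cccc4ncccc34)Oc3cc4ccccc4cc3-n3cccc32)CC1` gives 774 nM
- compound 3 `O=C(OC1=C(c2cccc3ncccc23)Oc2cc3ccccc3cc2-n2cccc21)C1CCNCC1` is still to be measured

Within the data shown here, compound 2 stands level with the one other measured compound. The gap is a 1.8-fold lower number from compound 1 to compound 2 (0.25 log units; within the scatter) and no more. Going on to compound 3, the change is piperidin-4-yl in place of 4-methylpiperazin-1-yl on a carbonyl carbon, counted in full as piperidin-4-yl in place of 4-methylpiperazin-1-yl on a carbonyl carbon here. Among the measured compounds shown here, one measured step bears on this, made on the same carbonyl carbon, and it is a 1.8-fold lower number from compound 1 to compound 2 (0.25 log units; within the scatter) for 4-methylpiperazin-1-yl in place of (4-(diethylamino)-1-methylbutyl)amino. For the measured compounds named here, no measured compound carries piperidin-4-yl, so that single step is thin support. In this assay no step beyond the scatter is therefore expected, in either direction. The expected step is a 1.0-fold higher number from compound 2 to compound 3 (0.01 log units; within the scatter) as estimated here. For compound 3 the estimated value is 800 nM with an expected range from 300 nM to 2000 nM as its ends.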

Compound 3, half-maximal inhibitory concentration: 6150 nM
Beside the measured number, compound 3's estimate is 7.7-fold (0.89 log units) below it; the measured number lies above the stated range.
By their numbers in this assay, from the lowest: compounds 2 and 1 (each within the scatter of the next); then compound 3.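

In this assay this position on the carbonyl carbon now gives a step beyond the scatter: a 7.9-fold higher number from compound 2 to compound 3 (0.90 log units; beyond the scatter) for piperidin-4-yl in place of 4-methylpiperazin-1-yl. The earlier change at the same place stayed within the scatter, whereas compound 3 also stands apart from the (4-(diethylamino)-1-methylbutyl)amino compound, with a 4.5-fold higher number from compound 1 to compound 3 (0.65 log units; beyond the scatter) as the second step beyond the scatter, so piperidin-4-yl is the only group shown here that separates from the others. No measurement shown ties this step to any one feature of the change.

Still open, on these data alone, is whether the higher number follows the piperidin-4-yl ring as such or its hydrogen-bond donor. A 1-methylpiperidin-4-yl group or a piperazin-1-yl group on the same carbonyl carbon would separate those two readings.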